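The compounds below may be only part of what the source reports. "The series", "measured", "known", "first", "only" and "open" are said of these compounds alone.

Of the compounds shown here, three have so far been tested in an ADME assay on ECV-304 cells (Homo sapiens) for cytotoxicity, read by MTT assay, with a stated time of 72 h (on this read-out higher numbers stand for weaker inhibition and lower numbers for stronger inhibition), and none has yet given an actual number. Compound 1, `COc1ccc(C2=C(c3cc(OC)c(OC)c(OC)c3)C(=O)CC2O[SiH2]C(C)(C)C)cc1`, reads > 100 ug/mL, which is a limit of the assay. Compound 2, `C=CCOc1cc(C2=C(c3cc(OC)c(OC)c(OC)c3)C(=O)C(O)C2)ccc1OC`, reads > 100 ug/mL, again a limit. Compound 3, `COc1ccc(C2=C(c3cc(OC)c(OC)c(OC)c3)C(=O)C(O)C2)cc1NC(=O)c1ccccc1`, reads > 100 ug/mL, also a limit. All three therefore sit together at the limit of > 100 ug/mL in this assay, at which 3 of the 3 values shown sit, and compound 3 has no number of its own to start from.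

Compound 4, `COc1ccc(C2=C(c3cc(OC)c(OC)c(OC)c3)C(=O)C(O)C2)cc1F`, differs from compound 3 in one place: fluoro in place of benzamido on an aromatic carbon. Fluoro takes the place of benzamido on an aromatic carbon, ortho to a methoxy group, so a large group gives way to a single atom.

Among the compounds with values here, one measured step bears on this change: a step that the two limits leave unreadable from compound 2 to compound 3, with benzamido in place of allyloxy on an aromatic carbon. It offers no size and no direction to carry over. Swapping a group on this ring has so far only left the reading at the limit, so no step beyond the usual scatter is expected, and another limit is the likeliest report. The expected step is a number no higher from compound 3 to compound 4 (the limit leaves the size open). Compound 4 is estimated at 100 ug/mL, with an expected range from 30 ug/mL to 200 ug/mL.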

Compound 4, half-maximal inhibitory concentration: 19.5 ug/mL
For compound 4 the middle estimate is 5.1-fold (0.71 log units) above the measured one; measured number below the stated range.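

In this assay, the aromatic carbon ortho to a methoxy group turns out to be a place where a change can be read: with fluoro there, the result is an at least 5.1-fold lower number from compound 3 to compound 4 (0.70 log units; beyond the scatter). Measured against the allyloxy compound, the same position gives an at least 5.1-fold lower number from compound 2 to compound 4 (0.70 log units; beyond the scatter), so a lower number appears whether fluoro replaces benzamido or allyloxy. Both steps give only a minimum size, and compound 4 is the one compound shown to have moved off the limit where the others remain: the limit of > 100 ug/mL in this assay, at which 3 of the 4 values shown sit.

What the compounds shown cannot separate is whether the lower number comes from fluoro itself or simply from the loss of a larger group, and a chloro group, a methyl group, an amine or a plain hydrogen on this same carbon would help to tell these apart. Going by these compounds, it also remains open how far the number would fall with other small groups here, and whether a different position on this ring would respond to fluoro in the same way.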